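A few compounds are considered here, and "the series" means these few. Any claim that something is new, unique, unknown or untested is made for them only; others in the source may bear on it.

Compound 1 `CCCn1c(=O)c2nc(-c3cnn(Cc4cc(F)ccc4Cl)c3)[nH]c2n(CCC)c1=O` gives 4800 nM in an in vitro assay on HEK293 cells for displacement of a labelled ligand from adenosine receptor A2b (Homo sapiens) (a lower number here means a stronger inhibitor, a higher number a weaker inhibitor), the highest of the three numbers. Compound 3 `CCCCn1c(=O)c2nc(-c3cnn(Cc4ccccc4)c3)[nH]c2n(CCCC)c1=O` comes nearest with 980 nM, and compound 2 `CCCn1c(=O)c2[nH]c(-c3cnn(Cc4ccccc4)c3)nc2n(CCC)c1=O` lies furthest away with 11 nM. Each of these differs from compound 1 in more than one place. No single change between measured compounds can be read off, and the numbers only show the spread.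

Compound 4 `CCCn1c(=O)c2nc(-c3cnn(Cc4cccc(F)c4F)c3)[nH]c2n(CCC)c1=O` carries the change (2,3-difluorophenyl in place of 2-chloro-5-fluorophenyl on a saturated chain carbon bound to an aromatic nitrogen). Two small substituted benzyl groups are exchanged here, so compound 4 is expected to move only modestly, toward a lower number; the step of a 1.9-fold lower number from compound 1 to compound 4 (0.28 log units; within the scatter) is estimated to lie near the edge of the scatter. Compound 4 is expected at 2500 nM, within 600 nM to 10000 nM.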

Compound 4, inhibition constant: 240 nM
Compound 4: middle estimate off by 10-fold (1.02 log units), on the high side; measured number below the stated range.
By their numbers in this assay, from the lowest: compound 2; then compound 4; then compound 3; then compound 1.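

In this assay, 2,3-difluorophenyl in place of 2-chloro-5-fluorophenyl on a saturated chain carbon bound to an aromatic nitrogen gives a 20-fold lower number from compound 1 to compound 4 (1.30 log units; beyond the scatter), so this position responds strongly even to an exchange between two groups of 8 heavy atoms. The change removes chlorine and adds fluorine, with no hydrogen-bond donors or acceptors on either group. No available evidence bears on this result. The compounds shown leave open whether the loss of chlorine or the placement of fluorine carries the step, and how a methoxy or nitrile group on the benzyl ring would read here.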